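A few compounds are considered here, and "the series" means these few. Any claim that something is new, unique, unknown or untested is made for them only; others in the source may bear on it.

Compound 1 `CS(=O)(=O)N1C(=O)COC12C=CC(=O)C=C2`: > 10000 nM
Compound 2 `Cc1ccc(S(=O)(=O)N2C(=O)C(C)OC23C=CC(=O)C=C3)cc1`: 1100 nM

The starting point is a functional assay on MDA-MB-231 cells (Homo sapiens) for inhibition, read by sulforhodamine B assay, with a stated time of 74 h; a lower number here means a stronger inhibitor, a higher number a weaker inhibitor. In this test, compound 1 gives > 10000 nM. That reading is a limit of the assay and not a number, so compound 1 has no exact position on the scale.

Compound 3 `Cc1ccccc1S(=O)(=O)N1C(=O)COC12C=CC(=O)C=C2` keeps the core of compound 1 but has 2-methylphenyl in place of methyl on a sulfonyl sulfur.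

Among the compounds with values here, no measured step shows this exact change on its own. Within the data shown here, the only guide is compound 2, which has an aromatic ring on its sulfonyl sulfur and gives 1100 nM. A large step towards stronger inhibition in this assay is therefore expected, well beyond the scatter. The expected step is an at least 5.5-fold lower number from compound 1 to compound 3 (0.74 log units; beyond the scatter). For compound 3 the estimate is 1800 nM, with an expected range of 500 nM to 7000 nM.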

Compound 3, half-maximal inhibitory concentration: > 10000 nM
Compound 3: only a limit was reported (the forecaster's own chance of this, stated with the estimate: 12%); middle value at least 5.5-fold (0.74 log units) away from the limit.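

In this assay, compound 1 and compound 3 each give only a limit and not a number, so no step can be read between them: the limit of > 10000 nM in this assay, at which 2 of the 3 values shown sit.

The compounds shown leave open whether 2-methylphenyl in place of methyl on a sulfonyl sulfur changes inhibition at all.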